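Tetrazolylphenyl replacing pyridinyl on the piperidine nitrogen substituent

The source may hold more compounds than are shown below. What is called first, only, known or untested is meant among the compounds shown, and "the series" means these compounds.

Measured so far:
compound 1 `COc1cc(C(=O)O)ccc1CN1CCC[C@H](OCc2cc(Cl)cc(Cl)c2)[C@@H]1c1ccccc1` gives 62000 nM in an assay on isolated protein for activation of cGMP-dependent protein kinase 1 (Homo sapiens), read by ADP-Glo, with stated times of 120 min and 40 min; on this read-out lower numbers stand for an effect already at smaller amounts and higher numbers for an effect only at larger amounts of compound;
compound 2 `Clc1cc(Cl)cc(CO[C@H]2CCCN(Cc3cccnc3)[C@H]2c2ccccc2)c1` gives 112000 nM;
compound 3 `Clc1cc(Cl)cc(CO[C@H]2CCCN(Cc3ccncc3)[C@H]2c2ccccc2)c1` gives > 200000 nM.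

Compound 3 sits at a limit of the assay, the value > 200000 nM being one and not a number; this is the limit of > 200000 nM in this assay, at which 1 of the 3 values shown sits. It therefore has no fixed place among the numbers, only the floor implied by its steps.

The step to compound 4 `Clc1cc(Cl)cc(CO[C@H]2CCCN(Cc3ccc(-c4nn[nH]n4)cc3)[C@H]2c2ccccc2)c1` is 4-(2H-tetrazol-5-yl)phenyl in place of pyridin-4-yl on a saturated chain carbon bound to an amine nitrogen in a ring. Among the compounds with values here, it reverses, in spirit, the step of an at least 3.2-fold higher number from compound 1 to compound 3 (0.50 log units; beyond the scatter), which took the 4-carboxy-2-methoxyphenyl group away and is the only step here beyond the scatter. The steps of a 1.8-fold higher number from compound 1 to compound 2 (0.26 log units; within the scatter) and an at least 1.7-fold higher number from compound 2 to compound 3 (0.25 log units; that floor lies within the scatter) stay within the scatter, so the aryl group on that chain carbon moves the read-out only modestly unless an acid-bearing group is involved, as in compound 1 with 62000 nM.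

Compound 4 carries the tetrazolyl group on the phenyl ring, and compound 4 is therefore expected to return toward the region of compound 1, giving an estimated 80000 nM with a range from 25000 nM to 200000 nM. The expected step is an at least 2.5-fold lower number from compound 3 to compound 4 (0.39 log units; beyond the scatter), that is, a lower number, though the limit at compound 3 makes its size uncertain.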

Compound 4, half-maximal effective concentration: 74000 nM
For compound 4 the middle estimate is 1.1-fold (0.03 log units) above the measured one; the measured number falls inside the stated range.
By their numbers in this assay, from the lowest: compounds 1, 4 and 2 (each within the scatter of the next). At a limit, above all of these: compound 3.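

In this assay, 4-(2H-tetrazol-5-yl)phenyl on a saturated chain carbon bound to an amine nitrogen in a ring gives an at least 2.7-fold lower number from compound 3 to compound 4 (0.43 log units; beyond the scatter), the second group after 4-carboxy-2-methoxyphenyl to be separated from pyridin-4-yl beyond the scatter. Compound 3 stands at a limit of the assay, so the size of that step is only a floor: the limit of > 200000 nM in this assay, at which 1 of the 4 values shown sits.

Against the other two groups the change separates nothing, with a 1.5-fold lower number from compound 2 to compound 4 (0.18 log units; within the scatter) and a 1.2-fold higher number from compound 1 to compound 4 (0.08 log units; within the scatter), so the carboxy and methoxy groups of compound 1 are not needed to hold this level, and pyridin-3-yl in compound 2 holds it as well.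

The compounds shown leave open whether a plain 4-carboxyphenyl group, without the methoxy group, would sit at the same level, and whether the methoxy group could be added to the tetrazolyl-bearing phenyl ring with any effect on the number. Also open, from the compounds shown here alone, is whether a longer chain between the ring nitrogen and the aryl group, or a sulfonamide in place of the tetrazole, would move the number beyond the scatter from compound 1 and compound 4.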